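Adding a Methyl on the Chain Carbon of Compound 1

The source may hold more compounds than are shown below. What is called first, only, known or untested is meant among the compounds shown, and "the series" means these compounds.

In a functional assay on the whole organism (strain Swiss) with Mus musculus as the target, in the maximal electroshock model, with a stated time of 0.25 h, at a dose of 300 mg/kg by the intraperitoneal route (on this read-out lower numbers stand for a weaker effect and higher numbers for a stronger effect at the one dose given), compound 1 `CC(C(=O)N1CCN(c2ccc(Cl)cc2)CC1)N1C(=O)CCC1=O` gives 100%. Compound 2 `CC(C(=O)N1CCN(c2ccccc2F)CC1)N1C(=O)CCC1=O` gives 100% in this assay, and compound 3 `CC(C(=O)N1CCN(c2cccc(F)c2)CC1)N1C(=O)CCC1=O` gives 100%. Compound 1 stands level with both of them: no change at the digits printed from compound 1 to compound 2 (within the scatter) and no change at the digits printed from compound 1 to compound 3 (within the scatter), and likewise no change at the digits printed from compound 2 to compound 3 (within the scatter). All three share one core and differ only in the group on the amine nitrogen in a ring, and all three reach the full effect at the dose given.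

Compound 4 `CCC(C(=O)N1CCN(c2ccc(Cl)cc2)CC1)N1C(=O)CCC1=O` is not yet measured. It differs from compound 1 by methyl in place of hydrogen on a saturated chain carbon, two bonds along the chain from an amide-type nitrogen in a ring and a carbonyl carbon. Within the data shown here, none of the measured steps touches this part of the molecule; each of them changed only the group on the amine nitrogen in a ring, and each stayed within the scatter. There is therefore no direct guide for the size of this step, only the observation that the shared core carrying the chain has held the full effect in every measured compound. The expected step of no change at the digits printed from compound 1 to compound 4 (within the scatter) is none beyond the scatter, though a drop cannot be ruled out. For compound 4 the estimate in this assay is 100%, within 75% to 100%.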

Compound 4, a percentage reported as activity, at one dose (the size of the read-out at that dose, not a potency): 0%
Beside the measured number, compound 4's estimate is 100 percentage points above it; measured number outside the range, below it.
By their numbers in this assay, from the lowest: compound 4; then compounds 1, 2 and 3 (each within the scatter of the next).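

In this assay, the saturated chain carbon, two bonds along the chain from an amide-type nitrogen in a ring and a carbonyl carbon, proves far more sensitive than the group on the amine nitrogen in a ring: methyl in place of hydrogen there gives a number 100 percentage points lower from compound 1 to compound 4 (beyond the scatter), while every earlier step stayed within the scatter. The same difference read one bond further out is methyl to ethyl, so a single added carbon is enough to separate full effect from none at this one dose in this pair. Nothing available explains this loss.

Still open, from the compounds shown here alone, is whether the loss carries over to the 2-fluorophenyl and 3-fluorophenyl compounds 2 and 3. Also open, going by these compounds, is how this position responds to a plain hydrogen in place of the methyl of compound 1, or to a longer chain such as propyl.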